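The source may report more compounds than this note shows. Statements on the series, on what has been measured and on what is new or still open speak of the compounds shown alone.

Compound 1 `CCOC(=O)c1c(-c2cccc(C)c2)[nH]c2cc(OC)ccc2c1=O`: 48000 nM
Compound 2 `CCOC(=O)c1c(-c2ccc(C(C)(C)C)cc2)[nH]c2cc(OC)ccc2c1=O`: 2000 nM
Compound 3 `CCOC(=O)c1c(-c2cccc(C(F)(F)F)c2)[nH]c2cc(OC)ccc2c1=O`: 19000 nM

In a physicochemical assay for solubility, in phosphate buffer, at pH 7.4 (on this read-out higher numbers stand for higher solubility and lower numbers for lower solubility), compound 2 has the lowest of the three values, 2000 nM. The open case is compound 4 `CCOC(=O)c1c(-c2ccc(Cl)cc2)[nH]c2cc(OC)ccc2c1=O`, with chloro in place of tert-butyl on an aromatic carbon, para to a large group: chloro in place of tert-butyl on an aromatic carbon. Within the data shown here, the only measured single-place step is a 2.5-fold lower number from compound 1 to compound 3 (0.40 log units; beyond the scatter), a modest one with trifluoromethyl in place of methyl, and it involves neither group in question. It therefore bears only loosely. The two compounds without tert-butyl, compound 1 at 48000 nM and compound 3 at 19000 nM, both stand well higher, which points upward. A rise beyond the scatter is expected in this assay, estimated as a 7.0-fold higher number from compound 2 to compound 4 (0.85 log units; beyond the scatter). For compound 4 the estimate is 14000 nM, with an expected range of 5000 nM to 40000 nM.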

Compound 4, solubility: 3000 nM
The estimate for compound 4 lay 4.7-fold (0.67 log units) above the measured number; measured number outside the range, below it.
By their numbers in this assay, from the lowest: compounds 2 and 4 (each within the scatter of the next); then compound 3; then compound 1.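

In this assay, chloro in place of tert-butyl on an aromatic carbon, para to a large group, gives a 1.5-fold higher number from compound 2 to compound 4 (0.18 log units; within the scatter), so the low number of compound 2 does not depend on tert-butyl alone. 4-Chlorophenyl in place of 3-methylphenyl gives a 16-fold lower number from compound 1 to compound 4 (1.20 log units; beyond the scatter), but this step changes both the group and its place, and the two cannot be separated. Nothing available explains either step.

Still open, as far as these compounds go, is how an amine or a carboxylic acid on this aromatic carbon would read. Also open, from the compounds shown here alone, is whether chloro and methyl differ when held at one place.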